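The compounds below may be only part of what the source reports. "The series", "measured", "known", "first", "only" and "open" are said of these compounds alone.

In a functional assay on PC-3 cells (Homo sapiens) for inhibition, read by colorimetric assay and MTT assay, with a stated time of 72 h (on this read-out higher numbers stand for weaker inhibition and lower numbers for stronger inhibition), compound 1 `C=CCCCCOc1ccc(OC)cc1-c1cnc(OCCC=C)n1C` gives 43000 nM and compound 2 `C=CCCCCOc1ccccc1-c1cnc(OCCCC=C)n1C` gives 28000 nM, two values within the scatter of each other. Compound 3 `C=CCCCCOc1ccccc1-c1cnc(OC)n1C` differs from compound 2 by hydrogen in place of but-3-en-1-yl on a saturated chain carbon bound to an oxygen on an aromatic ring, so that (pent-4-en-1-yl)oxy becomes methoxy. For the measured compounds named here, no measured pair shows this change in this assay, so the size of the step remains uncertain. The expected change, a 1.8-fold higher number from compound 2 to compound 3 (0.25 log units; within the scatter), is a small one toward weaker inhibition, and it may not clear the scatter. For compound 3 the estimated value is 50000 nM, with an expected range of 15000 nM to 150000 nM.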

Compound 3, half-maximal inhibitory concentration: 86000 nM
For compound 3 the middle estimate is 1.7-fold (0.24 log units) below the measured one; the range from low to high includes it.
By their numbers in this assay, from the lowest: compounds 2, 1 and 3 (each within the scatter of the next, the first and the last beyond it).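

For the compounds shown here, the change from (pent-4-en-1-yl)oxy to methoxy reads in this assay as a 3.1-fold higher number from compound 2 to compound 3 (0.49 log units; beyond the scatter) and is the first step that can be read, so this place on the shared core responds to the change, toward weaker inhibition. Loss of but-3-en-1-yl therefore has a modest but visible cost in this series. Nothing on hand accounts for the step.

Going by these compounds, whether chain length or the double bond matters remains open. A saturated pentyl chain, an ethoxy group or a chain ending in an amine would help separate these.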